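Urea end-group variation on the shared core

The source may hold more compounds than are shown below. What is called first, only, known or untested is meant among the compounds shown, and "the series" means these compounds.

The shared core of this series appears in compound 1 `COc1cc(NC(C)CCCNC(=O)NNC(=O)N(CCO)CCO)c2ncccc2c1`, compound 2 `COc1cc(NC(C)CCCNC(=O)Nc2ccc(Cl)c(C(F)(F)F)c2)c2ncccc2c1` and compound 3 `COc1cc(NC(C)CCCNC(=O)N(C)C(c2ccccc2)c2ccccc2)c2ncccc2c1`, which differ only in the group carried on the amide-type nitrogen of the urea. In a functional assay on MIA PaCa-2 cells (Homo sapiens) for inhibition, read by MTT assay, with a stated time of 4 days (on this read-out higher numbers stand for weaker inhibition and lower numbers for stronger inhibition), compound 2 gives 4000 nM, the lowest of the two numbers reported. Compound 3 gives 21000 nM in this assay. For compound 1 the assay reports only a limit, > 250000 nM; see (the limit of > 250000 nM in this assay, at which 1 of the 3 values shown sits). Among the compounds with values here, the one step measured at this position is an at least 62-fold lower number from compound 1 to compound 2 (1.79 log units; beyond the scatter), which shows how strongly the number depends on what sits there.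

Compound 4 `COc1cc(NC(C)CCCNC(=O)NN)c2ncccc2c1` has not yet been measured. The change from compound 2 is amino in place of 4-chloro-3-(trifluoromethyl)phenyl on an amide-type nitrogen. This removes the 4-chloro-3-(trifluoromethyl)phenyl entirely and leaves a bare amino on that nitrogen, an end-group closer in kind to that of compound 1 than to those of compound 2 or compound 3. The step of an at least 62-fold lower number from compound 1 to compound 2 (1.79 log units; beyond the scatter) therefore bears on it directly, run in reverse, and a large rise in the number is expected in this assay, of a size comparable to that step. Compound 4 is expected to give 150000 nM, with a range of 30000 nM to 250000 nM. The expected step of a 38-fold higher number from compound 2 to compound 4 (1.57 log units; beyond the scatter) is estimated to carry compound 4 to a number that the assay may well report only as a limit.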

Compound 4, half-maximal inhibitory concentration: >= 250000 nM
Compound 4 gave a limit, no number (the forecaster's own chance of this, stated with the estimate: 45%); middle value at least 1.6-fold (0.22 log units) from the limit.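

In this assay, amino in place of 4-chloro-3-(trifluoromethyl)phenyl on the amide-type nitrogen gives an at least 62-fold higher number from compound 2 to compound 4 (1.79 log units; beyond the scatter), so a bare amino end-group, without the bis(2-hydroxyethyl)carbamoyl carried by compound 1, is enough to lose any readable number. Compound 4 gives >= 250000 nM, which is a limit of the assay and not a number: the limit of >= 250000 nM in this assay, at which 1 of the 4 values shown sits.

The step joining compound 1 and compound 4 cannot be read, so the bis(2-hydroxyethyl)carbamoyl shows no measurable effect here, and among these four compounds only compound 2 and compound 3, whose end-groups carry aromatic rings, return actual numbers.

Still open, going by these compounds, is whether an unsubstituted phenyl on the same nitrogen keeps a number like that of compound 2, which would separate the contribution of the ring from that of the chloro and trifluoromethyl groups. Also open, on these data alone, is where small non-aromatic end-groups such as methyl or cyclohexyl fall between the number of compound 2 and the limit of compound 4.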